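This account rests on a few compounds, and the source may have more. Where it says the series, first, only, none or still open, it means among the compounds named here.

Measured in a functional assay on HeLa cells (Homo sapiens) for antiproliferative activity, read by MTT assay, with a stated time of 72 h; on this read-out higher numbers stand for weaker inhibition and lower numbers for stronger inhibition:
- compound 1 `COc1cc(C(=O)c2sc3ccccc3c2-c2ccccc2)cc(OC)c1OC`: 1900 nM
- compound 2 `COc1cc(C(=O)c2sc3ccccc3c2-c2ccc(F)cc2)cc(OC)c1OC`: 3000 nM
- compound 3 `COc1ccccc1-c1c(C(=O)c2cc(OC)c(OC)c(OC)c2)sc2ccccc12`: 5000 nM

Compound 3 holds the highest of the three numbers in this assay. Only a 2.6-fold higher number from compound 1 to compound 3 (0.42 log units; beyond the scatter) separates it from a neighbour as a modest step, while a 1.7-fold higher number from compound 2 to compound 3 (0.22 log units; within the scatter) does not set the pair apart.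

The next compound is compound 4 `CCOc1ccc(-c2c(C(=O)c3cc(OC)c(OC)c(OC)c3)sc3ccccc23)cc1`, with 4-ethoxyphenyl in place of 2-methoxyphenyl on an aromatic carbon.

Going by the values given here, no measured compound carries an ethoxy group, so the steps bear on this change only indirectly. The closest is the exchange of one substituted phenyl for another, a 1.7-fold higher number from compound 2 to compound 3 (0.22 log units; within the scatter). Also relevant are a 1.6-fold higher number from compound 1 to compound 2 (0.20 log units; within the scatter), for a substituent named at the 4 position of the phenyl, and a 2.6-fold higher number from compound 1 to compound 3 (0.42 log units; beyond the scatter), for the 2-methoxyphenyl group that leaves. On these steps, compound 4 is expected to fall nearer to compound 1 at 1900 nM and compound 2 at 3000 nM than to compound 3, though with three values this expectation is weakly supported.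

The expected move is a modest one toward a lower number, a 2.5-fold lower number from compound 3 to compound 4 (0.40 log units; beyond the scatter).

The estimate for compound 4 is 2000 nM, with an expected range of 400 nM to 6000 nM.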

Compound 4, half-maximal inhibitory concentration: 3000 nM
The estimate for compound 4 lay 1.5-fold (0.18 log units) below the measured number, and the stated range covers the measured number.
By their numbers in this assay, from the lowest: compounds 1, 2, 4 and 3 (each within the scatter of the next, the first and the last beyond it).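

In this assay, ethoxy on the phenyl ring at this position, on the aromatic carbon two ring bonds from the ring sulfur, does not separate compound 4 from its neighbours: a 1.6-fold higher number from compound 1 to compound 4 (0.20 log units; within the scatter) and no change at the digits printed from compound 2 to compound 4 (within the scatter) leave hydrogen, fluoro and ethoxy undistinguished on this read-out. Going by these compounds alone, the exchange of 2-methoxyphenyl for 4-ethoxyphenyl, a 1.7-fold lower number from compound 3 to compound 4 (0.22 log units; within the scatter) as printed, also stays within the scatter, so a 2.6-fold higher number from compound 1 to compound 3 (0.42 log units; beyond the scatter) remains the only step that lies beyond it, and compound 4 adds no second such step. No measurement in hand accounts for these values.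

The step to 4-ethoxyphenyl changes both the place of the oxygen substituent on the phenyl ring and the chain it carries, so a 4-methoxyphenyl or 2-ethoxyphenyl group would be needed to read these two changes apart. Also open, from the compounds shown here alone, is whether an amine, a carboxylic acid or a chain longer than ethoxy on this phenyl ring would move the number beyond the scatter in either direction.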